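Swapping the halogenated ring on a chalcone-type chain

The source may report more compounds than this note shows. Statements on the series, on what has been measured and on what is new or still open speak of the compounds shown alone.

Measured compounds:
- compound 1, `O=C(COc1ccc(C(=O)/C=C/c2ccccc2Br)cc1)N[C@H]1CCOC1=O`: 3260 nM
- compound 2, `Cc1cc(Cl)ccc1NCC(=O)N[C@H]1CCOC1=O`: > 64000 nM
- compound 3, `O=C(CNc1ccc(F)cc1)N[C@H]1CCOC1=O`: > 64000 nM

Three compounds share a lactam-bearing core and were tested in a functional assay on PC-3 cells (Homo sapiens) for antiproliferative activity, read by MTT assay, with a stated time of 72 h; on this read-out lower numbers stand for stronger inhibition and higher numbers for weaker inhibition. Compound 1 gives 3260 nM and is the only one of the three with a real number. Compound 2 reaches only (the limit of > 64000 nM in this assay, at which 2 of the 3 values shown sit), which is a limit of the assay rather than a measurement. Compound 3 likewise stops at its limit, > 64000 nM, so it too gives no number. Going by the values given here, compound 1 therefore stands alone as the sole measurable point, and no step between two measured compounds can be drawn from these data.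

Compound 4, `O=C(COc1ccc(C(=O)/C=C/c2ccc(Cl)cc2Cl)cc1)N[C@H]1CCOC1=O`, has not yet been measured. It differs from compound 1 in one place: 2,4-dichlorophenyl in place of 2-bromophenyl on a double-bonded chain carbon bound to a double-bonded chain carbon. Both the group that leaves and the group that enters are halogenated six-membered aromatic rings of carbon only, with no donors or acceptors and no charge, so the change is modest in size.

Among the compounds with values here, with no measured step to lean on, the expected step of a 1.5-fold lower number from compound 1 to compound 4 (0.17 log units; within the scatter) is small, in either direction, and not clearly beyond the scatter. Compound 4 is therefore estimated at 2200 nM, with a range from 600 nM to 8000 nM.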

Compound 4, half-maximal inhibitory concentration: 8040 nM
The estimate for compound 4 lay 3.7-fold (0.56 log units) below the measured number; measured number above the stated range.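

In this assay, going by these compounds alone, this place on the chain is the first where a change can be read as a number, and swapping the ring there gives a 2.5-fold higher number from compound 1 to compound 4 (0.39 log units; beyond the scatter). Both rings are halogenated six-membered aromatic rings of carbon only, with no hydrogen-bond donors or acceptors and no net charge, so the number moved even though those counts stayed the same, and it moved towards weaker inhibition with 2,4-dichlorophenyl. Nothing measured here explains why the step goes this way.

The swap changes both the kind of halogen and the number of halogens on the ring, so this single pair cannot separate the two changes, and it gives no view of a plain phenyl ring or of a ring carrying an amine or a carboxylic acid at the same place. On these data alone, the part played by the rest of the chain also stays open, as only compound 1 and compound 4 give real numbers and the other values are limits of the assay rather than measurements: the limit of > 64000 nM in this assay, at which 2 of the 4 values shown sit.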